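A Carboxyphenyl in Place of Thiophene on the Shared Core

The source may hold more compounds than are shown below. What is called first, only, known or untested is meant among the compounds shown, and "the series" means these compounds.

The three measured compounds share one core and differ only in the aromatic group on the five-membered ring with four nitrogens. Compound 3 `CCCCCCCCc1ccc(OCC(=O)Cn2nnc(-c3cccs3)n2)cc1` in an assay on microsomes from brain for inhibition of Fatty-acid amide hydrolase 1 (Rattus norvegicus), read by fluorescence and HPLC, with a stated time of 60 min (on this read-out lower numbers stand for stronger inhibition and higher numbers for weaker inhibition), gives 32 nM, the second highest of the three numbers. Compound 2 `CCCCCCCCc1ccc(OCC(=O)Cn2nnc(-c3ccncc3)n2)cc1` gives 24 nM, and a 1.3-fold higher number from compound 2 to compound 3 (0.12 log units; within the scatter). Compound 1 `CCCCCCCCc1ccc(OCC(=O)Cn2nnc(-c3cccc(S(=O)(=O)N(C)C)c3)n2)cc1` gives 420 nM, and a 13-fold lower number from compound 1 to compound 3 (1.12 log units; beyond the scatter). Compound 4 `CCCCCCCCc1ccc(OCC(=O)Cn2nnc(-c3cccc(C(=O)O)c3)n2)cc1` has not been measured; the change is 3-carboxyphenyl in place of thiophen-2-yl on an aromatic carbon. Among the compounds with values here, the step that bears on it is the one from compound 1, where a phenyl carrying a substituent at the 3-position gave the highest number of the set, and likewise an 18-fold lower number from compound 1 to compound 2 (1.24 log units; beyond the scatter). A rise beyond the scatter is therefore expected, a 9.4-fold higher number from compound 3 to compound 4 (0.97 log units; beyond the scatter). Compound 4 is estimated at 300 nM, within 60 nM to 1500 nM.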

Compound 4, half-maximal inhibitory concentration: 36 nM
Compound 4: the middle estimate sits 8.3-fold (0.92 log units) above what was measured; measured number outside the range, below it.
By their numbers in this assay, from the lowest: compounds 2, 3 and 4 (each within the scatter of the next); then compound 1.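

In this assay the 3-carboxyphenyl group shows no separation from thiophen-2-yl or pyridin-4-yl at this place on the shared core, with a 1.1-fold higher number from compound 3 to compound 4 (0.05 log units; within the scatter) and a 1.5-fold higher number from compound 2 to compound 4 (0.18 log units; within the scatter) both within the scatter. A phenyl carrying a substituent therefore does not by itself bring the high number of compound 1, since carboxy in place of dimethylsulfamoyl gives a 12-fold lower number from compound 1 to compound 4 (1.07 log units; beyond the scatter) on the same phenyl. Nothing available explains this result. Still open, going by these compounds, is whether a plain phenyl, the methyl ester of the acid in compound 4, or an unsubstituted sulfonamide would fall with compound 4 or with compound 1.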